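The source may report more compounds than this note shows. Statements on the series, on what has been measured and on what is new or still open speak of the compounds shown alone.

Measured in a functional assay for inhibition, with Homo sapiens as the target (a higher number here means a weaker inhibitor, a lower number a stronger inhibitor), so far:
Compound 1 `OCc1cc(-c2ccccc2)c2ccc(OCc3cccc(C4(O)CCOCC4)c3)cc2c1` gives 9 nM
Compound 2 `CC(O)c1cc(-c2ccccc2)c2ccc(OCc3cccc(C4(O)CCOCC4)c3)cc2c1` gives 28 nM
Compound 3 `COC(C)c1cc(-c2ccccc2)c2ccc(OCc3cccc(C4(O)CCOCC4)c3)cc2c1` gives 41 nM

Compound 3 sits level with compound 2, as a 1.5-fold higher number from compound 2 to compound 3 (0.17 log units; within the scatter) shows. Compound 1 has the lowest number of the set, and compound 3 stands apart from it in a 4.6-fold higher number from compound 1 to compound 3 (0.66 log units; beyond the scatter) on the weaker side.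

Compound 4 `COC(=O)c1cc(-c2ccccc2)c2ccc(OCc3cccc(C4(O)CCOCC4)c3)cc2c1` carries methoxycarbonyl in place of 1-methoxyethyl on an aromatic carbon at the same place on the shared core. Going by the values given here, no measured pair makes this exact change, so the evidence is indirect. Adding a methyl to the chain carbon cost a modest amount in a 3.1-fold higher number from compound 1 to compound 2 (0.49 log units; beyond the scatter) and methoxycarbonyl has no such methyl, which hints at a slightly lower number. Capping the oxygen with methyl did little in a 1.5-fold higher number from compound 2 to compound 3 (0.17 log units; within the scatter) as well. The carbonyl itself is new to this set, so the direction remains uncertain, and no step beyond the scatter is expected in this assay here. The expected step is a 1.4-fold lower number from compound 3 to compound 4 (0.14 log units; within the scatter) and it could go either way. Compound 4 is estimated at 30 nM with an expected range from 10 nM to 90 nM in this test.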

Compound 4, half-maximal inhibitory concentration: 3 nM
Compound 4: middle estimate off by 10-fold (1.00 log units), on the high side, and the stated range ends above it.
By their numbers in this assay, from the lowest: compound 4; then compound 1; then compounds 2 and 3 (each within the scatter of the next).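

Replacing 1-methoxyethyl with methoxycarbonyl on this aromatic carbon gives a 14-fold lower number from compound 3 to compound 4 (1.14 log units; beyond the scatter), the largest step in the set, so this position responds far more strongly to the type of group than the earlier changes to the chain and its oxygen suggested. Methoxycarbonyl also outperforms both groups that carry a hydroxyl, with a 9.3-fold lower number from compound 2 to compound 4 (0.97 log units; beyond the scatter) against 1-hydroxyethyl and a 3.0-fold lower number from compound 1 to compound 4 (0.48 log units; beyond the scatter) against hydroxymethyl, which makes compound 4 the strongest inhibitor of the four. Nothing measured here explains why this group does so well.

The compounds shown cannot separate the contribution of the carbonyl from that of the methoxy oxygen attached to it. A carboxylic acid, a primary amide or an acetyl group at this place would help to tell these apart.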